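Replacing an ethyl ester with a cyclohexyl amide

The compounds below may be only part of what the source reports. "The series", "measured", "known", "first", "only" and "open" are said of these compounds alone.

Among the compounds with values here, compound 1 `CCOC(=O)c1ccc(/C=C/C(=O)c2cc(OC)ccc2OC)cc1` gives 4490 nM in a functional assay on NTUB1 cells (Homo sapiens) for cytotoxicity, read by MTT assay, with a stated time of 72 h (on this read-out lower numbers stand for stronger inhibition and higher numbers for weaker inhibition), which places it second highest of the three numbers measured so far: compound 2 `COc1ccc(OC)c(C(=O)/C=C/c2ccc(C(=O)OCC=C(C)C)cc2)c1` gives 13400 nM and compound 3 `CCCNC(=O)c1ccc(/C=C/C(=O)c2cc(OC)ccc2OC)cc1` gives 2260 nM. Compound 4 `COc1ccc(OC)c(C(=O)/C=C/c2ccc(C(=O)NC3CCCCC3)cc2)c1` differs from compound 1 by cyclohexylamino in place of ethoxy on a carbonyl carbon. Within the data shown here, two measured steps bear on this change. The exchange of the ester for an amide is seen in a 2.0-fold lower number from compound 1 to compound 3 (0.30 log units; within the scatter), while enlarging the ester alkyl group is seen in a 3.0-fold higher number from compound 1 to compound 2 (0.47 log units; beyond the scatter). Compound 4 carries an amide, so compound 3 with 2260 nM is taken as the closer guide. On that basis a 1.8-fold lower number from compound 1 to compound 4 (0.25 log units; within the scatter) is expected, a step within the scatter. Compound 4 is therefore estimated at 2500 nM, with a range from 1000 nM to 7000 nM.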

Compound 4, half-maximal inhibitory concentration: 2250 nM
Compound 4: middle estimate off by 1.1-fold (0.05 log units), on the high side, within the range that was stated.
By their numbers in this assay, from the lowest: compounds 4, 3 and 1 (each within the scatter of the next); then compound 2.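

In this assay, cyclohexylamino on the carbonyl carbon reads like propylamino, with a 1.0-fold lower number from compound 3 to compound 4 (0.00 log units; within the scatter), so a six-membered ring in place of the open propyl chain on the amide-type nitrogen registers no separation. Against the ethyl ester, the change gives a 2.0-fold lower number from compound 1 to compound 4 (0.30 log units; within the scatter), while against the larger ester it gives a 6.0-fold lower number from compound 2 to compound 4 (0.77 log units; beyond the scatter), the only one of these steps beyond the scatter. Nothing available explains these steps. On these data alone, whether a benzylamino group or a free carboxylic acid on this carbonyl carbon would separate from these compounds remains open.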